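The source may hold more compounds than are shown below. What is called first, only, known or untested is meant among the compounds shown, and "the series" means these compounds.

Compound 1 `N=C(N)NCCC[C@H](NC(=O)CN(c1nc(Cl)nc2[nH]cnc12)C1CC1)C(=O)O`: 27.6%
Compound 2 `CC[C@H](C)[C@H](NC(=O)CN(c1nc(Cl)nc2[nH]cnc12)C1CC1)C(=O)O`: 27.4%
Compound 3 `NCCCC[C@H](NC(=O)CN(c1nc(Cl)nc2[nH]cnc12)C1CC1)C(=O)O`: 28.8%

In a functional assay on the whole organism (Tail, strain ICR) with Mus musculus as the target, in the tail flick test, with a stated time of 90 min, at a dose of 25 umol/kg by the oral route (a lower number here means a weaker effect, a higher number a stronger effect of the compound at the dose given), compound 3 carries the highest of the three numbers, yet the steps of a number 1.2 percentage points higher from compound 1 to compound 3 (within the scatter) and a number 1.4 percentage points higher from compound 2 to compound 3 (within the scatter) both lie within the scatter, so none of the three compounds can be set apart from the others. Compound 4 `CSCC[C@H](NC(=O)CN(c1nc(Cl)nc2[nH]cnc12)C1CC1)C(=O)O` differs from compound 3 by methylsulfanyl in place of 2-aminoethyl on a saturated chain carbon, three bonds along the chain from an amide-type nitrogen and a carbonyl carbon. Among the measured compounds shown here, the steps that bear on this are a number 1.2 percentage points higher from compound 1 to compound 3 (within the scatter), a number 1.4 percentage points higher from compound 2 to compound 3 (within the scatter) and a number 0.2 percentage points lower from compound 1 to compound 2 (within the scatter), each of which exchanged the group on this same chain and none of which moved the read-out beyond the scatter. The step of a number 0.8 percentage points lower from compound 3 to compound 4 (within the scatter) is therefore expected to stay within the scatter as well. Compound 4 is estimated at 28%, within a range of 18% to 38%.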

Compound 4, a percentage reported as activity, at one dose (the size of the read-out at that dose, not a potency): 14%
The estimate for compound 4 lay 14 percentage points above the measured number; measured number below the stated range.
By their numbers in this assay, from the lowest: compound 4; then compounds 2, 1 and 3 (each within the scatter of the next).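

In this assay, among the compounds shown here, the 2-(methylsulfanyl)ethyl chain of compound 4 is the first at this position to move the read-out beyond the scatter, with the steps of a number 14.8 percentage points lower from compound 3 to compound 4 (beyond the scatter), a number 13.4 percentage points lower from compound 2 to compound 4 (beyond the scatter) and a number 13.6 percentage points lower from compound 1 to compound 4 (beyond the scatter). The sec-butyl chain of compound 2 carries no nitrogen yet stays within the scatter of compound 1 and compound 3, so the absence of nitrogen does not by itself go with the lower number. Nothing available explains this drop.

The compounds shown leave open whether the sulfur atom itself matters, which a 2-methoxyethyl or n-butyl chain at this place would test. They also leave open whether the carboxylic acid present throughout is needed.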